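Swapping methyl for trifluoromethyl on a fatty acid receptor agonist

A few compounds are considered here, and "the series" means these few. Any claim that something is new, unique, unknown or untested is made for them only; others in the source may bear on it.

Of the compounds shown here, three sharing one core have been measured in a functional assay on CHO cells for agonist activity at Free fatty acid receptor 1 (Homo sapiens), read by FLIPR and calcium flux, tested at 100 nM; on this read-out lower numbers stand for a weaker effect and higher numbers for a stronger effect at the one concentration tested. Compound 1 `O=C(O)CC1COc2cc(OCc3nnc(-c4ccccc4)s3)ccc21` gives 3.36%, and compound 2 `O=C(O)CC1COc2cc(OCc3ncc(-c4ccccc4)s3)ccc21` gives 5.26%; these two numbers lie within the scatter of each other, so nothing separates them. Compound 3 `Cc1cccc(-c2nc(C)c(COc3ccc4c(c3)OCC4CC(=O)O)s2)c1` gives 47.2%, the highest of the three numbers, and its gap to each of the other two is beyond the scatter.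

The next compound, compound 4 `Cc1nc(-c2cccc(C(F)(F)F)c2)sc1COc1ccc2c(c1)OCC2CC(=O)O`, differs from compound 3 in one place only: trifluoromethyl in place of methyl on an aromatic carbon. Among the compounds with values here, no pair differing in just this way has yet been measured, so the size of such a step is unknown here. With nothing in the data pointing one way, the step from compound 3 to compound 4 in this assay is expected to be none beyond the scatter, giving a number 2.8 percentage points higher from compound 3 to compound 4 (within the scatter). Compound 4 is therefore expected to give about 50% in this assay, with a range from 20% to 80%.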

Compound 4, a percentage reported as activity, at one concentration (the size of the read-out at that concentration, not a potency): 35.7%
The estimate for compound 4 lay 14.3 percentage points above the measured number, and the stated range covers the measured number.
By their numbers in this assay, from the lowest: compounds 1 and 2 (each within the scatter of the next); then compound 4; then compound 3.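

Within the data shown here, this is the first pair here that differs in one place only, and in this assay putting trifluoromethyl in place of methyl on an aromatic carbon gives a number 11.5 percentage points lower from compound 3 to compound 4 (beyond the scatter). The read-out at this position, meta to a large group, therefore depends on which group sits there, although the step is modest and compound 4 still gives 35.7%. Nothing available bears on why the number falls with this change.

Going by these compounds, with only methyl and trifluoromethyl to compare, it remains open whether a plain hydrogen, a chlorine atom or a methoxy group here would give a number closer to that of compound 3 or compound 4. On these data alone, it is also open whether the same swap would give a step of similar size at another position on this ring.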